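Amide nitrogen substitution in a TRPM8 agonist series

The source may report more compounds than this note shows. Statements on the series, on what has been measured and on what is new or still open speak of the compounds shown alone.

Measured compounds:
compound 1 `CON(Cc1cccs1)C(=O)COc1ccc(C)cc1` — 10 nM
compound 2 `O=C(COc1ccc2c(c1)CCC2)N(Cc1cccs1)c1ccn[nH]1` — 0.001 nM

In an assay on HEK293 cells for agonist activity at transient receptor potential cation channel subfamily M member 8 (Homo sapiens), read by fluorescence and calcium flux, with a stated time of 15 min (on this read-out higher numbers stand for an effect only at larger amounts of compound and lower numbers for an effect already at smaller amounts), compound 1 gives 10 nM, the highest of the two numbers in hand. Going by the values given here, compound 2, with a different aryloxy group and a heteroaryl group on the amide nitrogen, gives 0.001 nM; the two compounds differ in more than one place, so no single step separates them, and the gap between them is beyond the scatter.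

Compound 3 `Cc1ccc(OCC(=O)N(Cc2cccs2)c2ccccc2)cc1` is not yet measured. It differs from compound 1 in one place: phenyl in place of methoxy on an amide-type nitrogen. Compound 2 shows that an aromatic group on this nitrogen is compatible with very low values, but its second difference leaves the contribution of the nitrogen substituent alone unresolved. The step of a 5.0-fold lower number from compound 1 to compound 3 (0.70 log units; beyond the scatter) is expected to run towards lower values, moderately beyond the scatter. Compound 3 is expected at 2 nM, within 0.1 nM to 30 nM.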

Compound 3, half-maximal effective concentration: 23 nM
Compound 3: middle estimate off by 12-fold (1.06 log units), on the low side, and the stated range covers the measured number.
By their numbers in this assay, from the lowest: compound 2; then compound 1; then compound 3.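

In this assay, phenyl in place of methoxy on the amide-type nitrogen gives a 2.3-fold higher number from compound 1 to compound 3 (0.36 log units; beyond the scatter) and so moves the number modestly upward on the core of compound 1. An unsubstituted phenyl on this nitrogen is thus tolerated but brings no gain over methoxy, so the very low value of compound 2 cannot be credited to just any aromatic ring at this position. No measured data shown here account for the direction of this step.

Whether the heteroaryl group on the nitrogen or the different aryloxy group accounts for the low value of compound 2 remains unresolved, as no compound shown separates the two. A pyridyl ring or a plain methyl on this nitrogen of the core of compound 1 would show how far the outcome depends on the group placed there.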